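Working notes on cytotoxicity across four related compounds

The compounds below may be only part of what the source reports. "The series", "measured", "known", "first", "only" and "open" are said of these compounds alone.

Compound 1 `O=C1/C(=C/c2ccc(Cl)cc2)CCC/C1=C\c1ccccc1[N+](=O)[O-]` is assessed in an ADME assay on HPLF cells (Homo sapiens) for cytotoxicity, with a stated time of 24 h; on this read-out lower numbers stand for higher toxicity in this test and higher numbers for lower toxicity in this test. In this assay compound 1 gives > 400000 nM, which is a limit of the assay rather than a number. Compound 2 `CN(C)c1ccc(/C=C2\CCC/C(=C\c3ccccc3[N+](=O)[O-])C2=O)cc1` carries dimethylamino in place of chloro on an aromatic carbon. In this assay compound 2 gives > 400000 nM, again a limit and not a number. The step that the two limits leave unreadable from compound 1 to compound 2 therefore has no readable size. Compound 3 `O=C1/C(=C/c2ccc(Cl)cc2)CCC/C1=C\c1cccc([N+](=O)[O-])c1` has the same atoms as compound 1 joined differently; the difference between the two cores is not broken down here. In this assay, going by the values given here, compound 3 gives 38000 nM, the only number among the three. Two of the three values rest at the limit of > 400000 nM in this assay, at which 2 of the 3 values shown sit.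

Compound 4 `CN(C)c1ccc(/C=C2\CCC/C(=C\c3cccc([N+](=O)[O-])c3)C2=O)cc1` has not been measured in this assay. It differs from compound 3 by dimethylamino in place of chloro on an aromatic carbon, the same change as that from compound 1 to compound 2, with the place described in identical words. The earlier step, a step that the two limits leave unreadable from compound 1 to compound 2, supplies no size to lean on, so the expectation rests on compound 3 at 38000 nM and on the change itself. The step of a 1.3-fold higher number from compound 3 to compound 4 (0.12 log units; within the scatter) is expected to be modest. Compound 4 is estimated at 50000 nM, between 12000 nM and 250000 nM.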

Compound 4, half-maximal cytotoxic concentration: > 400000 nM
Compound 4 gave a limit, no number; the forecaster's own chance of this, stated with the estimate: 25%; middle value at least 8.0-fold (0.90 log units) away from the limit.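

Dimethylamino in place of chloro on an aromatic carbon gives an at least 10-fold higher number from compound 3 to compound 4 (1.02 log units; beyond the scatter) in this assay, a large step on this core, with its full size left open. Compound 4 gives > 400000 nM, which is a limit of the assay and not a number. The steps from compound 1 to compound 2 and from compound 2 to compound 4 cannot be read, so the change has a size on one core only, and whether that size carries from one core to the other is not shown: the limit of > 400000 nM in this assay, at which 3 of the 4 values shown sit.

Only chloro and dimethylamino stand at this place in the compounds shown, so it remains open whether the step follows from the loss of chloro or from the arrival of dimethylamino. A methoxy group, a primary amine or a carboxylic acid at the same place would help to separate the two readings, provided the values fall short of the limit.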